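Swapping Trifluoromethyl for Fluoro on a Shared Core

The compounds below may be only part of what the source reports. "The series", "measured", "known", "first", "only" and "open" are said of these compounds alone.

Of the compounds shown here, three have been measured in an assay on tissue (M109 cells) for inhibition of Indoleamine 2,3-dioxygenase 1 (Mus musculus), read by fluorescence, with a stated time of 18 h (on this read-out lower numbers stand for stronger inhibition and higher numbers for weaker inhibition), and a fourth awaits its number. Compound 1, `CCC(c1nc2ncc(Cl)cc2[nH]1)[C@H]1CC[C@@H](c2ccnc3ccc(C(F)(F)F)cc32)CC1`, gives 3 nM in this assay. Compound 3, `CCC(c1nc2ncc(Cl)cc2[nH]1)[C@H]1CC[C@@H](c2ccnc3ccc(F)cc32)CC1`, is the same molecule with one change: fluoro in place of trifluoromethyl on an aromatic carbon. Compound 3 gives 5 nM. This change gave a 1.7-fold higher number from compound 1 to compound 3 (0.22 log units; within the scatter). Compound 2, `CCC(Nc1nnc(-c2ccc(OC)cc2)o1)[C@H]1CC[C@@H](c2ccnc3ccc(C(F)(F)F)cc32)CC1`, carries a different core; how it differs from compound 1 is not broken down here. In this assay compound 2 gives 6 nM, a number that sits within the scatter of both compound 1 and compound 3, so no order among the three can be read from the numbers.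

Compound 4, `CCC(Nc1nnc(-c2ccc(OC)cc2)o1)[C@H]1CC[C@@H](c2ccnc3ccc(F)cc32)CC1`, is compound 2 with the same kind of change applied: fluoro in place of trifluoromethyl on an aromatic carbon. The place of the change is described in the same words for both pairs, so the two changes are treated as the same.

For the measured compounds named here, on this basis the step from compound 2 to compound 4 is expected to resemble the one already seen from compound 1 to compound 3, which lay within the scatter. The expected step is a 1.7-fold higher number from compound 2 to compound 4 (0.22 log units; within the scatter), because compound 2 starts from 6 nM and the earlier change gave a 1.7-fold higher number from compound 1 to compound 3 (0.22 log units; within the scatter). Compound 4 is therefore estimated at 10 nM, with a range from 4 nM to 25 nM.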

Compound 4, half-maximal inhibitory concentration: 31 nM
Beside the measured number, compound 4's estimate is 3.1-fold (0.49 log units) below it, and the stated range ends below it.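

On the core of compound 2, fluoro in place of trifluoromethyl has a clear effect in this assay, with a 5.2-fold higher number from compound 2 to compound 4 (0.71 log units; beyond the scatter). The same change therefore cannot be assumed to have the same size on both cores, and the gap between the two steps is larger than repeat measurements alone would be expected to produce: the same change on two cores in this assay, a 1.7-fold higher number (0.22 log units; within the scatter) from compound 1 to compound 3 and a 5.2-fold higher number (0.71 log units; beyond the scatter) from compound 2 to compound 4, 3.1-fold (0.49 log units) apart, beyond the scatter of two such steps. This does not show why the two cores respond differently, and two matched pairs cannot tell how the change would behave on a further core, nor which of the two steps is the more typical.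

The compounds shown carry only trifluoromethyl or fluoro at this aromatic carbon, so it remains open how either core would respond to a plain hydrogen, a chlorine, a methyl or a nitrile in that place. A third core carrying trifluoromethyl and fluoro in turn would help show whether the step stays small, as on the core of compound 1, or grows beyond the scatter, as on the core of compound 2.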